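The source may report more compounds than this note shows. Statements on the series, on what has been measured and on what is new or still open speak of the compounds shown alone.

Compound 1 `CCCS(=O)(=O)N1CC=C(c2ccc3c(c2)CC(C2CCN(C(=O)OC(C)C)CC2)O3)CC1` and compound 2 `CCCS(=O)(=O)N1CC=C(c2ccc3c(c2)CC(C2CCN(S(=O)(=O)CCC)CC2)O3)CC1` share one core and differ only at an amine nitrogen in a ring. In a functional assay on HEK293 cells with Glucose-dependent insulinotropic receptor (Homo sapiens) as the target, read by cAMP accumulation, with a stated time of 60 min (a lower number here means a smaller maximal response, a higher number a larger maximal response), compound 1 gives 61%, while compound 2 gives 43%, the lowest of the two numbers. Going by the values given here, the only measured step is a number 18 percentage points lower from compound 1 to compound 2 (beyond the scatter). Among the compounds with values here, compound 3 `CCCS(=O)(=O)N1CC=C(c2ccc3c(c2)CC(C2CCN(C(=O)OC4CCCCC4)CC2)O3)CC1` differs from compound 2 by cyclohexyloxycarbonyl in place of propylsulfonyl on an amine nitrogen in a ring, a change of the same kind run backwards, though the entering group is not the one found in compound 1. Because the step of a number 18 percentage points lower from compound 1 to compound 2 (beyond the scatter) went downward when isopropoxycarbonyl left, a rise of similar size is expected here, estimated as a number 15 percentage points higher from compound 2 to compound 3 (beyond the scatter). Compound 3 is therefore expected to give 58%, within 42% to 74%.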

Compound 3, largest response reached (Emax), in percent of the reference or control that the assay uses: 56%
Estimate against measurement, compound 3: 2 percentage points above; the measured number falls inside the stated range.
By their numbers in this assay, from the lowest: compound 2; then compounds 3 and 1 (each within the scatter of the next).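

In this assay, the change at this amine nitrogen gives a number 13 percentage points higher from compound 2 to compound 3 (beyond the scatter), so the higher response returns with a second oxycarbonyl group and does not depend on isopropoxycarbonyl alone. Exchanging isopropyl for cyclohexyl on the oxygen gives a number 5 percentage points lower from compound 1 to compound 3 (within the scatter), so these two groups cannot be told apart here. No available evidence explains the gap between the oxycarbonyl groups and propylsulfonyl. The compounds shown leave open how an acetyl or benzyl group on this nitrogen would compare.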